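A few compounds are considered here, and "the series" means these few. Any claim that something is new, unique, unknown or untested is made for them only; others in the source may bear on it.

Measured compounds:
compound 1 `O=c1[nH]c2ncc(Br)nc2n1C1CC1`: "not determined" (no result reported) in an ADME assay on microsomes from liver (Homo sapiens), read by LC-MS, with a stated time of 90 min; on this read-out higher numbers stand for higher hepatic extraction and lower numbers for lower hepatic extraction
compound 2 `CCC(CC)n1c(=O)[nH]c2nccnc21`: "not determined" (no result reported)
compound 3 `CCC(CC)n1c(=O)[nH]c2ncc(C(F)(F)F)nc21`: < 0.2

Within the data shown here, compound 1 and compound 2 carry no number in this assay, so compound 3 is the only one with a reading. For compound 3 that reading is a limit of the assay, not a number: < 0.2. That limit is where compound 3 stands among the values shown (the limit of < 0.2 in this assay, at which 1 of the 3 values shown sits). Compound 4 `C=Cc1cnc2[nH]c(=O)n(C(CC)CC)c2n1` has not yet been measured. It differs from compound 3 in one place: vinyl in place of trifluoromethyl on an aromatic carbon. Among the measured compounds shown here, no step between two measured compounds is available, so there is nothing to lean on for the size of the change. Compound 4 is expected to give 0.3, within 0.1 to 0.6, in this assay. The expected step a number at least 0.10 higher from compound 3 to compound 4 (that floor lies within the scatter) points upward, a little beyond the scatter, though a result at the same limit would not surprise.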

Compound 4, hepatic extraction ratio: 0.5
Compound 4: middle estimate off by 0.20, on the low side, and the stated range covers the measured number.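

In this assay, among these compounds, putting vinyl in place of trifluoromethyl on this aromatic carbon gives a number at least 0.30 higher from compound 3 to compound 4 (beyond the scatter) and so offers the one readable step in the set, showing that the read-out responds to a change at this position. Compound 3 reads as a limit of the assay and not a number, so the step has a floor but no fixed size: the limit of < 0.2 in this assay, at which 1 of the 4 values shown sits.

Going by these compounds, whether the double bond of vinyl or the loss of trifluoromethyl matters more stays open. On these data alone, how an amine, a nitrile or an ethyl chain would read on this carbon also stays open.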